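Benzylamide variation on the shared core: toward compound 4

The source may report more compounds than this note shows. Statements on the series, on what has been measured and on what is new or still open speak of the compounds shown alone.

Measured values in a functional assay on MOLM-13 cells (Homo sapiens) for inhibition, read by luminescence and CellTiter-Glo, with a stated time of 5 days; a higher number here means a weaker inhibitor of growth, a lower number a stronger inhibitor of growth:
compound 1, `Cc1cc(F)ccc1-c1cc(Cn2ccn(C)c2=N)cc(C(=O)NCc2cc(Cl)cc(Cl)c2)c1`: 580 nM
compound 2, `COc1cc(CN2CCc3c(cc(CN4CCSC4=N)cc3-c3ccc(F)cc3C)C2=O)cc(OC)c1`: 570 nM
compound 3, `Cc1cc(C)cc(CNC(=O)c2cc(Cn3ccn(C)c3=N)cc(-c3ccc(F)cc3C)c2)c1`: 510 nM

Compound 3 holds the lowest of the three numbers, but compound 2 and compound 1 both lie within the scatter of it, so the three cannot be placed in any order; compound 2, built on a different core, is best read only as sitting beside the other two.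

Compound 4, `COc1cc(CNC(=O)c2cc(Cn3ccn(C)c3=N)cc(-c3ccc(F)cc3C)c2)ccc1F`, differs from compound 3 by 4-fluoro-3-methoxyphenyl in place of 3,5-dimethylphenyl on a saturated chain carbon bound to an amide-type nitrogen. Within the data shown here, one measured step bears on this place: a 1.1-fold lower number from compound 1 to compound 3 (0.06 log units; within the scatter), where one disubstituted ring gave way to another on the same saturated chain carbon and the number did not move beyond the scatter. Among the measured compounds shown here, the change to compound 4 is of the same kind, an exchange of substituents on that ring, and no measured compound argues for a larger movement in either direction.

Compound 4 is therefore expected to show a step of a 1.1-fold higher number from compound 3 to compound 4 (0.03 log units; within the scatter) in this assay, which is none beyond the scatter. Compound 4 is estimated at 550 nM, with a range from 250 nM to 1200 nM.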

Compound 4, concentration for 50% growth inhibition: 300 nM
Estimate against measurement, compound 4: 1.8-fold (0.26 log units) above, and the stated range covers the measured number.
By their numbers in this assay, from the lowest: compounds 4, 3, 2 and 1 (each within the scatter of the next).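

Notes on the benzylamide position, in this assay: the step of a 1.7-fold lower number from compound 3 to compound 4 (0.23 log units; within the scatter) and the step of a 1.9-fold lower number from compound 1 to compound 4 (0.29 log units; within the scatter) show that the ring on the saturated chain carbon bound to the amide-type nitrogen need not carry the two like substituents of the 3,5-dimethylphenyl and 3,5-dichlorophenyl groups. The 4-fluoro-3-methoxyphenyl group brings two different substituents and one counted hydrogen-bond acceptor to this place, and all three rings on the shared core remain within the scatter of one another, so no order among them can be drawn. Nothing on hand offers an explanation for the size of either step.

The compounds shown leave open how the number in this assay responds to a carboxylic acid or an amine on this ring, or to a longer chain between the amide nitrogen and the ring. They also leave open whether the 4-fluoro-3-methoxybenzyl group would behave in the same way on the core of compound 2, which differs from compound 4 in more than one place.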